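This account rests on a few compounds, and the source may have more. Where it says the series, first, only, none or still open, it means among the compounds named here.

Measured in a functional assay on MKN-45 cells (Homo sapiens) for cytotoxicity; on this read-out lower numbers stand for stronger inhibition and higher numbers for weaker inhibition:

Compound 1 `COc1ccc(S(=O)(=O)N2CCc3cccc(NC(=O)c4cccs4)c32)cc1`: 31 nM
Compound 2 `COc1ccc(S(=O)(=O)N2CCc3cccc(NC(=O)c4ccc([N+](=O)[O-])cc4)c32)cc1`: 95 nM
Compound 3 `COc1ccc(S(=O)(=O)N2CCc3cccc(NC(=O)c4ccncc4)c32)cc1`: 8.8 nM

Compound 1 stands second highest of the three numbers in this assay. Its nearest neighbour is compound 2, reached by a 3.1-fold higher number from compound 1 to compound 2 (0.49 log units; beyond the scatter); its furthest is compound 3, reached by a 3.5-fold lower number from compound 1 to compound 3 (0.55 log units; beyond the scatter). Between the other two the gap is larger, an 11-fold lower number from compound 2 to compound 3 (1.03 log units; beyond the scatter).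

Compound 4 `COc1ccc(S(=O)(=O)N2CCc3cccc(NC(C)=O)c32)cc1` is the next member to be tested. Its difference from compound 1 is methyl in place of thiophen-2-yl on a carbonyl carbon. Among the measured compounds shown here, none of the measured steps removes the ring from the carbonyl carbon; all three swap one ring for another, and each such swap moved the number beyond the scatter in this assay, in both directions. For the measured compounds named here, the identity of the group on the carbonyl carbon therefore matters here, but no measured pair tells what a ring-free group does at that place. With the direction of the change undetermined by direct precedent, the estimate leans toward a weaker number, on the view that the aromatic group contributes, while keeping a wide range. The expected step is a 4.8-fold higher number from compound 1 to compound 4 (0.68 log units; beyond the scatter). For compound 4 the estimated value in this assay is 150 nM, with a range from 35 nM to 700 nM.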

Compound 4, half-maximal inhibitory concentration: 61 nM
Compound 4: the middle estimate sits 2.5-fold (0.39 log units) above what was measured; the measured number falls inside the stated range.
By their numbers in this assay, from the lowest: compound 3; then compounds 1, 4 and 2 (each within the scatter of the next, the first and the last beyond it).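

In this assay, replacing the ring on the carbonyl carbon with methyl leaves no separation from two of the ring-bearing compounds, with a 2.0-fold higher number from compound 1 to compound 4 (0.29 log units; within the scatter) and a 1.6-fold lower number from compound 2 to compound 4 (0.19 log units; within the scatter), even though those two compounds are themselves separated by a 3.1-fold higher number from compound 1 to compound 2 (0.49 log units; beyond the scatter). The one clear separation from the ring-free compound belongs to pyridin-4-yl, at a 6.9-fold higher number from compound 3 to compound 4 (0.84 log units; beyond the scatter), so among the groups compared here, a ring at this place does not by itself set a compound apart from methyl, and thiophen-2-yl and 4-nitrophenyl show no difference from it beyond the scatter. The data shown offer no independent measurement that accounts for this outcome.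

On these data alone, it remains open whether plain phenyl or pyridin-3-yl on the carbonyl carbon would stay with compound 3 or fall in with compound 4, which would show how far the result is specific to pyridin-4-yl. A longer chain such as propyl, or an amine such as dimethylaminomethyl, would test whether any ring-free group can reach the number of compound 3.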